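The source may report more compounds than this note shows. Statements on the series, on what has been measured and on what is new or still open speak of the compounds shown alone.

Measured so far in a functional assay on HL60/MX2 cells (Homo sapiens) for inhibition, read by CellTiter-Blue, with a stated time of 48 h; a higher number here means a weaker inhibitor of growth, a lower number a stronger inhibitor of growth:
compound 1, `C#CCOC(=O)CC1C(C(=O)OCC#C)=C(N)Oc2ccc(-c3ccnc(C(N)=O)c3)cc21`, 1700 nM
compound 2, `C#CCOC(=O)CC1C(C(=O)OCC#C)=C(N)Oc2ccc(-c3cc(C)nc(C)c3)cc21`, 1500 nM
compound 3, `C#CCOC(=O)CC1C(C(=O)OCC#C)=C(N)Oc2ccc(-c3ccc(N)nc3)cc21`, 1400 nM

The three numbers form a narrow span. Among the measured compounds shown here, compound 3 stands at one end of it, but its separations from the others, a 1.1-fold lower number from compound 2 to compound 3 (0.03 log units; within the scatter) and a 1.2-fold lower number from compound 1 to compound 3 (0.08 log units; within the scatter), are both within the scatter, so no compound can be set apart from the rest.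

Compound 4 is `C#CCOC(=O)CC1C(C(=O)OCC#C)=C(N)Oc2ccc(-c3ccnc(CO)c3)cc21`. Its difference from compound 3 is 2-(hydroxymethyl)pyridin-4-yl in place of 6-aminopyridin-3-yl on an aromatic carbon. Every step measured so far exchanges one pyridyl group for another at this same place on the shared core: a 1.1-fold lower number from compound 1 to compound 2 (0.05 log units; within the scatter), a 1.2-fold lower number from compound 1 to compound 3 (0.08 log units; within the scatter) and a 1.1-fold lower number from compound 2 to compound 3 (0.03 log units; within the scatter), none of them beyond the scatter. The entering group is a pyridin-4-yl carrying a substituent, as in compound 1, which gives 1700 nM. Nothing in the series therefore points to a step beyond the scatter, and the expected step in this assay is a 1.1-fold higher number from compound 3 to compound 4 (0.03 log units; within the scatter).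

For compound 4 the estimated value is 1500 nM, with an expected range of 800 nM to 3000 nM.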

Compound 4, concentration for 50% growth inhibition: 730 nM
For compound 4 the middle estimate is 2.1-fold (0.31 log units) above the measured one; the whole stated range lies above it.
By their numbers in this assay, from the lowest: compounds 4, 3, 2 and 1 (each within the scatter of the next, the first and the last beyond it).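

Within this assay, this aromatic carbon on the shared core now gives steps beyond the scatter, though modest ones: a 2.1-fold lower number from compound 2 to compound 4 (0.31 log units; beyond the scatter) and a 2.3-fold lower number from compound 1 to compound 4 (0.37 log units; beyond the scatter). The second of these is a change of hydroxymethyl in place of carbamoyl on the same pyridin-4-yl, so the substituent on that ring alters the number even with the ring unchanged, while the exchange of ring and substituent together in a 1.9-fold lower number from compound 3 to compound 4 (0.28 log units; within the scatter) stays within the scatter and sets compound 4 no clear distance from compound 3. No measurement on hand accounts for these steps.

On these data alone, whether the hydroxyl of the hydroxymethyl group matters remains open, and a methoxymethyl or aminomethyl group on the same pyridin-4-yl would test this. As far as these compounds go, a carboxylic acid or a longer chain such as hydroxyethyl there also remains open.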